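Methylating the ring amine of a weak nicotinic ligand

The source may hold more compounds than are shown below. What is called first, only, known or untested is meant among the compounds shown, and "the series" means these compounds.

Two spiro-fused compounds have been examined in an assay on cell membranes for displacement of a labelled ligand from Neuronal acetylcholine receptor; alpha4/beta2 (Rattus norvegicus); on this read-out lower numbers stand for stronger inhibition and higher numbers for weaker inhibition. Compound 1 `COC1=NOC2(CCC[N+](C)(C)C2)C1` gives 94000 nM, and compound 2 `BrC1=NOC2(CCCNC2)C1` gives 58000 nM; the two values lie within the usual scatter of each other, so neither can be set apart from the other. Compound 3 `CN1CCCC2(CC(Br)=NO2)C1` differs from compound 2 by methyl in place of hydrogen on an amine nitrogen in a ring. Within the data shown here, no step between measured compounds is available to guide this change, so the step of a 1.2-fold lower number from compound 2 to compound 3 (0.06 log units; within the scatter) is expected to be small, in either direction, and not clearly beyond the scatter. Compound 3 is therefore estimated at 50000 nM, with a range from 15000 nM to 200000 nM.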

Compound 3, inhibition constant: 44000 nM
Compound 3: middle estimate off by 1.1-fold (0.06 log units), on the high side; the range from low to high includes it.
By their numbers in this assay, from the lowest: compounds 3, 2 and 1 (each within the scatter of the next, the first and the last beyond it).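

On the amine nitrogen in the ring, methyl in place of hydrogen gives the first step measured at this position, a 1.3-fold lower number from compound 2 to compound 3 (0.12 log units; within the scatter) in this assay, so this change does not set the two compounds apart. No measurement at hand accounts for this result. As far as these compounds go, it remains open whether an ethyl or a benzyl group on this nitrogen would also stay within the scatter of compound 2. From the compounds shown here alone, it is also open how compound 3 would read with chlorine in place of its bromine.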